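Removing the hydroxymethyl from compound 3

A few compounds are considered here, and "the series" means these few. Any claim that something is new, unique, unknown or untested is made for them only; others in the source may bear on it.

In a functional assay on MCF7 cells (Homo sapiens) for inhibition (on this read-out higher numbers stand for weaker inhibition and lower numbers for stronger inhibition), compound 1 `CCCCCCCCCCCCCCCCCCOC[C@H](COP(=O)(O)O[C@H]1[C@@H](O)[C@@H](O)[C@H](O)C[C@H]1O)OC` gives 7200 nM while compound 2 `CCCCCCCCCCCCCCCCCCOC[C@H](COP(=O)(O)O[C@@H]1[C@H](O)[C@@H](CO)[C@@H](O)[C@H](O)[C@@H]1O)OC` gives 2000 nM and compound 3 `CCCCCCCCCCCCCCCCCCOC[C@H](COC(=O)O[C@@H]1[C@H](O)[C@@H](CO)[C@@H](O)[C@H](O)[C@@H]1O)OC` gives 12500 nM on the same read-out. Compound 3 thus lies within the scatter of compound 1 and beyond the scatter above compound 2. Compound 1 and compound 2 carry a phosphate link, whereas compound 3 carries a carbonate link.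

Compound 4 `CCCCCCCCCCCCCCCCCCOC[C@H](COC(=O)O[C@H]1[C@@H](O)[C@@H](O)[C@H](O)C[C@H]1O)OC` keeps the carbonate link of compound 3 and differs by hydrogen in place of hydroxymethyl on a saturated ring carbon in one place, hydrogen in place of hydroxymethyl on a saturated ring carbon. For the measured compounds named here, one measured step bears on this change and runs the opposite way: hydroxymethyl in place of hydrogen gave a 3.6-fold lower number from compound 1 to compound 2 (0.56 log units; beyond the scatter) with the phosphate link, a modest step. Reversed, that step points to a modest rise in the number in this assay for compound 4, toward weaker inhibition. Going by the values given here, no pair with the carbonate link has been measured, so the transfer is uncertain and a somewhat smaller step is allowed for. The expected step is a 2.8-fold higher number from compound 3 to compound 4 (0.45 log units; beyond the scatter) in the direction of weaker inhibition. Estimated for compound 4 is 35000 nM within an expected range of 14000 nM to 80000 nM on that read-out.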

Compound 4, half-maximal inhibitory concentration: 12000 nM
The estimate for compound 4 lay 2.9-fold (0.46 log units) above the measured number, outside the stated range (below it).
By their numbers in this assay, from the lowest: compound 2; then compounds 1, 4 and 3 (each within the scatter of the next).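

Notes on the hydroxymethyl position: in this assay, hydrogen in place of hydroxymethyl on this saturated ring carbon gives a 1.0-fold lower number from compound 3 to compound 4 (0.02 log units; within the scatter), so with the carbonate link the read-out does not separate the two groups. The earlier compounds shown here showed this position only with the phosphate link, where hydroxymethyl went with stronger inhibition, and that result does not carry over to the carbonate link, so the change depends on the link it is paired with: the same change on two cores in this assay, a 3.6-fold lower number (0.56 log units; beyond the scatter) from compound 1 to compound 2 and a 1.0-fold higher number (0.02 log units; within the scatter) from compound 4 to compound 3, 3.8-fold (0.57 log units) apart, beyond the scatter of two such steps. The hydroxymethyl at this place therefore cannot be scored as a fixed contribution across the series, and its benefit is documented only for the pair compound 1 and compound 2.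

The compounds shown do not tell why the two links behave differently, since there is one pair per link and the comparison rests on a single assay. Also open, going by these compounds, is whether an amine or a carboxylic acid at this ring carbon would separate from hydrogen with the carbonate link, and whether a longer chain in place of the hydroxymethyl would follow the same dependence on the link.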